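From 2-hydroxyethyl to cyclopropyl on an aromatic nitrogen

The compounds below may be only part of what the source reports. "The series", "measured", "known", "first", "only" and "open" are said of these compounds alone.

Measured so far:
- compound 1 `CCCn1cc2c(Oc3ccc(S(C)(=O)=O)cc3)cc(C(=O)Nc3cnc(C)cn3)cc2n1`: 14.2 10^-6 cm/s
- compound 2 `Cc1cnc(NC(=O)c2cc(Oc3ccc(S(C)(=O)=O)cc3)c3cn(CCO)nc3c2)cn1`: 6.3 10^-6 cm/s

In an ADME assay on MDCKII-LE cells (Canis lupus familiaris) for permeability (a lower number here means that the compound crosses the layer more slowly, a higher number that the compound crosses the layer faster), compound 2 has the lower of the two numbers, at 6.3 10^-6 cm/s. Compound 3 `Cc1cnc(NC(=O)c2cc(Oc3ccc(S(C)(=O)=O)cc3)c3cn(C4CC4)nc3c2)cn1` carries cyclopropyl in place of 2-hydroxyethyl on an aromatic nitrogen. For the measured compounds named here, one measured step bears on this change: a 2.3-fold lower number from compound 1 to compound 2 (0.35 log units; beyond the scatter), with hydroxy in place of methyl on a saturated chain carbon. Going by the values given here, compound 3 has no hydroxy either, though no measured compound shows cyclopropyl. A modest move back up in this assay is therefore expected, estimated as a 2.1-fold higher number from compound 2 to compound 3 (0.31 log units; beyond the scatter). For compound 3 the estimated value is 13 10^-6 cm/s, with an expected range of 7 10^-6 cm/s to 24 10^-6 cm/s.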

Compound 3, apparent permeability in the MDCKII-LE assay: 15.5 10^-6 cm/s
Compound 3: the middle estimate sits 1.2-fold (0.08 log units) below what was measured; low and high end bracket the measured number.
By their numbers in the MDCKII-LE assay, from the lowest: compound 2; then compounds 1 and 3 (each within the scatter of the next).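

In the MDCKII-LE assay, the change at this nitrogen gives a 2.5-fold higher number from compound 2 to compound 3 (0.39 log units; beyond the scatter), while a 1.1-fold higher number from compound 1 to compound 3 (0.04 log units; within the scatter) shows that cyclopropyl and propyl cannot be told apart on this read-out. The three-membered ring therefore matches the open propyl chain here, and the hydroxy-bearing chain remains the outlier among the three compounds. The same change carries a steep cost in a physicochemical assay for solubility, measured as kinetic solubility (on this read-out higher numbers stand for higher solubility and lower numbers for lower solubility), where compound 2 gives 24400 nM and compound 3 gives 500 nM, as the measurements show: the measured solubility of compound 2, 24400 nM, and of compound 3, 500 nM, a 49-fold lower number (1.69 log units; beyond the scatter)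

On these data alone, what remains open is whether any group on this nitrogen can give both good numbers at once. A 2-methoxyethyl group or a chain ending in an amine could test this.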